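The source may hold more compounds than are shown below. What is called first, only, known or untested is meant among the compounds shown, and "the series" means these compounds.

Compound 1 `CCC1C(=O)N(C)c2cnc(-n3ccc4cc(C(=O)NC)ccc43)nc2N1c1ccn(C)n1` and compound 2 `CCC1C(=O)N(C)c2cnc(-n3ccc4cc(F)ccc43)nc2N1c1ccn(C)n1` share one core and differ only on the fused ring, where compound 1 carries the change (methylcarbamoyl in place of fluoro on an aromatic carbon). In a functional assay on MCF7 cells (Homo sapiens) for antiproliferative activity, read by CCK-8 assay, with a stated time of 72 h (on this read-out lower numbers stand for stronger inhibition of growth and higher numbers for weaker inhibition of growth), compound 2 gives 24700 nM, and compound 1 gives 35400 nM; the step of a 1.4-fold higher number from compound 2 to compound 1 (0.16 log units; within the scatter) is small. Compound 3 `CC[C@@H]1C(=O)N(C)c2cnc(-n3ccc4cc(F)ccc43)nc2N1C1CCCC1` has a different core; how its core differs from that of compound 2 is not broken down here. In this assay compound 3 gives "not active" (no number reported), with no number given. Compound 4 `CC[C@@H]1C(=O)N(C)c2cnc(-n3ccc4cc(C(=O)NC)ccc43)nc2N1C1CCCC1` stands to compound 3 as compound 1 does to compound 2, carrying the same kind of change, (methylcarbamoyl in place of fluoro on an aromatic carbon). Because the step of a 1.4-fold higher number from compound 2 to compound 1 (0.16 log units; within the scatter) stayed within the scatter, compound 4 is expected to stay close to the weak result of compound 3. The expected value for compound 4 in this assay is 80000 nM, between 25000 nM and 300000 nM.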

Compound 4, concentration for 50% growth inhibition: 1000 nM
Estimate against measurement, compound 4: 80-fold (1.90 log units) above; the whole stated range lies above it.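

Within the data shown here, compound 3 has no number in this assay, and no step from it to compound 4 can be read. The compounds shown leave open how large the change from fluoro to methylcarbamoyl is on this core. No measured evidence accounts for the result.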